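Bromo in Place of Chloro: What to Expect for Compound 3

This account rests on a few compounds, and the source may have more. Where it says the series, first, only, none or still open, it means among the compounds named here.

Measured so far:
compound 1, `COCc1cc2cc(/C(=N\O)Nc3cccc(Br)c3)ccc2o1`, 2500 nM
compound 2, `O/N=C(/Nc1cccc(Cl)c1)c1ccc2oc(COCC3CC3)cc2c1`, 17600 nM

Of the compounds shown here, two have been tested in an assay on tissue (HeLa cells) for inhibition of Indoleamine 2,3-dioxygenase 1 (Homo sapiens), read by spectrophotometry; a higher number here means a weaker inhibitor, a lower number a stronger inhibitor. Compound 1 gives 2500 nM, while compound 2 gives 17600 nM, the highest of the two numbers; the gap between them lies beyond the usual scatter. The two compounds differ in more than one place, so nothing can be said about which part of the change accounts for the gap.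

Compound 3, `O/N=C(/Nc1cccc(Br)c1)c1ccc2oc(COCC3CC3)cc2c1`, has not yet been measured. It differs from compound 2 in one place only: bromo in place of chloro on an aromatic carbon. The change is small in size, and a halogen replaces a halogen. Among the compounds with values here, no pair of measured compounds isolates this exchange, so there is no measured step to lean on. The expectation is that the step from compound 2 to compound 3 in this assay will be modest and could fall either way, most likely toward a somewhat lower number, a 1.5-fold lower number from compound 2 to compound 3 (0.17 log units; within the scatter). Compound 3 is therefore estimated at 12000 nM, with a range from 5000 nM to 30000 nM.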

Compound 3, half-maximal inhibitory concentration: 3200 nM
Compound 3: middle estimate off by 3.8-fold (0.57 log units), on the high side; measured number below the stated range.
By their numbers in this assay, from the lowest: compounds 1 and 3 (each within the scatter of the next); then compound 2.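

In this assay, within the data shown here, the exchange of chloro for bromo on the aromatic carbon, which no earlier pair had isolated, now has a measured size: a 5.5-fold lower number from compound 2 to compound 3 (0.74 log units; beyond the scatter). A single halogen atom at this position of the 3-halophenyl group is therefore enough to move the number beyond the scatter, even though the entering and leaving groups match in heavy-atom count, hydrogen-bond donors, hydrogen-bond acceptors and charge. With bromo held in place, cyclopropyl in place of hydrogen on the saturated chain carbon bound to an oxygen gives a 1.3-fold higher number from compound 1 to compound 3 (0.11 log units; within the scatter), so of the two single steps now measured, only the halogen exchange lies beyond the scatter.

Nothing at hand says what lies behind the difference between chloro and bromo here. The compounds shown leave open whether the exchange keeps its size with hydrogen in place of cyclopropyl on that chain, and how iodo, methyl or trifluoromethyl would read on the same aromatic carbon.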